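A Methyl Group Added to a Cyclic Urea Imidazole

The source may report more compounds than this note shows. Statements on the series, on what has been measured and on what is new or still open speak of the compounds shown alone.

Compound 1, with the structure `CCOC(=O)N(C)CC#CCn1ccnc1`, and compound 2, with the structure `CCOC(=O)N(C)CC#CCn1cncc1C`, share a core in which an ethyl carbamate carries a methyl on the nitrogen and a four-carbon chain with a triple bond leads to an imidazole ring. The two were tested in a functional assay on the whole organism for agonist activity, with Mus musculus as the target; a lower number here means that less compound is needed, a higher number that more compound is needed for the effect. In this assay compound 1 reached only the limit > 100 mg/kg, which is a boundary of the measurement and not a number. Compound 2 likewise gave only the limit > 100 mg/kg. The change between them, (methyl in place of hydrogen on an aromatic carbon), therefore produced a step that the two limits leave unreadable from compound 1 to compound 2; the reason the step cannot be read is the limit of > 100 mg/kg in this assay, at which 2 of the 3 values shown sit.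

Compound 3, with the structure `O=C1NCCN1CC#CCn1ccnc1`, has a different core, in which a cyclic urea takes the place of the carbamate; the difference between the two cores is not broken down here. In this assay, among the measured compounds shown here, compound 3 gave 30 mg/kg, the only numerical value among the three measured compounds.

Compound 4, with the structure `Cc1cncn1CC#CCN1CCNC1=O`, has not yet been measured. It differs from compound 3 by methyl in place of hydrogen on an aromatic carbon, the same change as that from compound 1 to compound 2, since the two places are described in identical words. Because that earlier step was a step that the two limits leave unreadable from compound 1 to compound 2, the measured data give no guide to its size. The step from compound 3 to compound 4 is therefore expected to be small, about a 1.3-fold higher number from compound 3 to compound 4 (0.12 log units; within the scatter). Compound 4 is estimated to give about 40 mg/kg in this assay, likely between 10 mg/kg and 150 mg/kg.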

Compound 4, dose for half-maximal effect: > 100 mg/kg
Compound 4: a limit, no number; the forecaster's own chance of this, stated with the estimate: 25%; at least 2.5-fold (0.39 log units) between middle value and limit.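

On the cyclic urea core, methyl in place of hydrogen on an aromatic carbon gives an at least 3.3-fold higher number from compound 3 to compound 4 (0.52 log units; beyond the scatter) in this assay, so compound 4 needs clearly more compound for the effect than compound 3, and the true size of the step may be larger still. On the carbamate core, the same change between compound 1 and compound 2 gives a step that cannot be read, and the step on the cyclic urea core is known only from one side, because the measurements run into a ceiling: the limit of > 100 mg/kg in this assay, at which 3 of the 4 values shown sit. The result therefore shows a loss on one core, but it does not show that the change has the same effect, or a step of the same size, on the other core, since the limits of compound 1 and compound 2 leave room for either outcome.

The compounds shown leave open how a different group on the same aromatic carbon, such as ethyl, chlorine or a hydroxymethyl group, would compare with hydrogen and methyl. They also leave open whether a core carrying an amine or a carboxylic acid in place of the carbamate or the cyclic urea would respond to the methyl group in the same way.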